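The source may hold more compounds than are shown below. What is called first, only, known or untested is meant among the compounds shown, and "the series" means these compounds.

Measured so far:
compound 1 `CCCCCCCC/C=C\CCCCCCC(=O)c1ncc(-c2ccccc2)o1` — 320 nM
compound 2 `CCCCCCCC/C=C\CCCCCCC(=O)c1nc2c(C)cccc2o1` — > 100000 nM

Among the measured compounds shown here, compound 1 is the only member of the pair with a number in an assay on isolated protein for inhibition of Fatty-acid amide hydrolase 1 (Homo sapiens); a lower number here means a stronger inhibitor, a higher number a weaker inhibitor; in this assay compound 1 gives 320 nM. Compound 2 returns > 100000 nM, which is a limit of the assay and not a number. One of the two values shown therefore sits at the limit of > 100000 nM in this assay, at which 1 of the 2 values shown sits, so compound 1 stands alone as the single measured point of reference in this assay.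

Compound 3 `CCCCCCCC/C=C\CCCCCCC(=O)c1ncco1` is not yet measured. It differs from compound 1 in one place: hydrogen in place of phenyl on an aromatic carbon. For the measured compounds named here, no measured step covers this kind of change, so the size must be guessed from the one number in hand. The step from compound 1 to compound 3 is expected to be a 16-fold higher number from compound 1 to compound 3 (1.19 log units; beyond the scatter), toward weaker inhibition and beyond the usual scatter. Compound 3 is estimated at 5000 nM in this assay, with a range from 1000 nM to 30000 nM, and some chance of only a limit being reported.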

Compound 3, inhibition constant: 17 nM
The estimate for compound 3 lay 290-fold (2.47 log units) above the measured number; measured number outside the range, below it.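

In this assay, hydrogen in place of phenyl on the aromatic carbon next to the ring oxygen gives a 19-fold lower number from compound 1 to compound 3 (1.27 log units; beyond the scatter) and so marks a large move toward stronger inhibition. Phenyl at this position is therefore not required for inhibition, and compound 3 at 17 nM replaces compound 1 as the better reference point for further single changes. No measured property available here accounts for the size of this step.

Open, on these data alone, is whether a small group on this same carbon, such as methyl, chlorine or an amine, would keep the inhibition seen with hydrogen or lose it as phenyl does. Also open, as far as these compounds go, is whether the effect of this change would hold with a shorter chain on the carbonyl.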